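Replacing a ring carbamate with an oxadiazolylmethyl group

The source may hold more compounds than are shown below. What is called first, only, known or untested is meant among the compounds shown, and "the series" means these compounds.

Of the compounds shown here, three have been tested so far in a functional assay on isolated protein for agonist activity at Glucose-dependent insulinotropic receptor (Rattus norvegicus), read by HTRF and cAMP accumulation; a lower number here means that less compound is needed, a higher number that more compound is needed for the effect. Compound 1, `CC(C)(C)OC(=O)N1CCC(O[C@H]2CC[C@@H](Oc3ccc(S(C)(=O)=O)cc3)CC2)CC1`, gives 1390 nM. Compound 2, `CC(C)(C)OC(=O)N1CCC(O[C@H]2CC[C@H](Oc3ccc(S(C)(=O)=O)c(F)c3)CC2)CC1`, gives 167 nM. Compound 3, `CS(=O)(=O)c1cnc(O[C@H]2CC[C@H](OC3CCN(C(=O)OC4CCOC4)CC3)CC2)cn1`, gives 1500 nM, the highest of the three numbers; its value and that of compound 1 lie within the scatter of each other, while the number for compound 2 is clearly lower than that for compound 3.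

Compound 4, `CC(F)Cc1nc(CN2CCC(O[C@H]3CC[C@H](Oc4cnc(S(C)(=O)=O)cn4)CC3)CC2)no1`, differs from compound 3 in one place: (5-(2-fluoropropyl)-1,2,4-oxadiazol-3-yl)methyl in place of ((oxolan-3-yl)oxy)carbonyl on an amine nitrogen in a ring. Among the compounds with values here, no pair of measured compounds in this set differs in the same way, so the size of this step has to be judged without a direct precedent. The change exchanges a carbamate on the ring nitrogen for a basic-ring substituent of similar size with the same count of hydrogen-bond acceptors, and the rest of the molecule is untouched.

Compound 4 is expected to show a moderate drop in the number needed, with a step from compound 3 estimated at a 3.0-fold lower number from compound 3 to compound 4 (0.48 log units; beyond the scatter). The estimate for compound 4 is 500 nM, expected within a range from 100 nM to 3000 nM.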

Compound 4, half-maximal effective concentration: 267 nM
The estimate for compound 4 lay 1.9-fold (0.27 log units) above the measured number, and the stated range covers the measured number.
By their numbers in this assay, from the lowest: compounds 2 and 4 (each within the scatter of the next); then compounds 1 and 3 (each within the scatter of the next).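

In this assay, within the data shown here, the group on the amine nitrogen in the six-membered ring turns out to matter, with a 5.6-fold lower number from compound 3 to compound 4 (0.75 log units; beyond the scatter), and this pair gives the first reading of a single change, as none of the earlier compounds differed from one another in one place only. It also shows that a carbamate is not required at this position, since (5-(2-fluoropropyl)-1,2,4-oxadiazol-3-yl)methyl, which has no carbonyl on the ring nitrogen, takes the place of ((oxolan-3-yl)oxy)carbonyl and the number still falls, with no change in the count of hydrogen-bond acceptors or donors. No measurement at hand speaks to the reason for this step.

The step rests on one pair and exchanges the whole group at once, so the compounds shown do not separate the contribution of the fluorine, the five-membered aromatic ring or the methyl link to the nitrogen. As far as these compounds go, what a plain propyl chain in place of 2-fluoropropyl would give remains open, as does whether the same exchange would carry over to the core of compound 2.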